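Swapping an aminophenyl for a difluorophenyl on the shared core

This account rests on a few compounds, and the source may have more. Where it says the series, first, only, none or still open, it means among the compounds named here.

Measured so far:
compound 1 `COc1cc(-c2cc(/C=C/C(=O)c3ccc(N)cc3)[nH]n2)cc(OC)c1OC` with 67%
compound 2 `COc1ccc(-c2cc(/C=C/C(=O)c3cc(OC)c(OC)c(OC)c3)[nH]n2)cc1OC` with 80%
compound 3 `COc1ccc(-c2cc(/C=C/C(=O)c3ccc(N)cc3)[nH]n2)cc1` with 78%

All three were tested in a functional assay on RXF 393 cells (Homo sapiens) for cytotoxicity, read by sulforhodamine B assay, with a stated time of 48 h, tested at 1 uM; a lower number here means a stronger effect, a higher number a weaker effect of the compound at the concentration tested. Compound 1 gives the lowest number of the three, so its effect on the cells is the strongest of this small set. Compound 3 lies higher and compound 2 higher still, both differences beyond the usual scatter of this assay.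

The next compound, compound 4 `COc1cc(-c2cc(/C=C/C(=O)c3ccc(F)c(F)c3)[nH]n2)cc(OC)c1OC`, is not yet measured in this assay. It differs from compound 1 in one place: 3,4-difluorophenyl in place of 4-aminophenyl on a carbonyl carbon. Within the data shown here, the 4-aminophenyl is the only group among the three measured compounds that carries a hydrogen-bond donor on that aromatic ring, and its removal has not been tested directly, so no measured step tells how large the change will be.

With nothing to compare against, the expectation is a step of modest size, somewhat weakening, since compound 1 already stands at the strong end of the set and the 3,4-difluorophenyl brings no hydrogen-bond donor or acceptor; the step from compound 1 to compound 4 is estimated as a number 8 percentage points higher from compound 1 to compound 4 (within the scatter). Compound 4 is therefore expected to give 75% in this assay, within a range from 55% to 95%.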

Compound 4, a percentage reported as activity, at one concentration (the size of the read-out at that concentration, not a potency): 82%
Compound 4: the middle estimate sits 7 percentage points below what was measured; the range from low to high includes it.
By their numbers in this assay, from the lowest: compound 1; then compounds 3, 2 and 4 (each within the scatter of the next).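

In this assay, placing 3,4-difluorophenyl in place of 4-aminophenyl on a carbonyl carbon gives a number 15 percentage points higher from compound 1 to compound 4 (beyond the scatter) and so a weaker effect at the concentration tested. This is the first change shown that touches this position alone, with the rest of the molecule held the same, so the difference can be assigned to this one swap rather than to several changes at once. It shows that the group on this carbonyl carbon has a real bearing on the read-out and that, for this pair, the 4-aminophenyl is the better of the two, although nothing measured here connects the step to any particular property of either group.

Still open, as far as these compounds go, is whether the amine itself or the whole ring substitution matters, which a plain phenyl, a 4-hydroxyphenyl, a 4-methoxyphenyl or a 4-(dimethylamino)phenyl at this position could help to separate, while a 4-fluorophenyl could show whether one fluorine behaves like two. From the compounds shown here alone, it is also open whether the same swap would give a step of similar size on the core of compound 3, which carries a different pattern of methoxy groups.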